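Fluoro-for-hydrogen step on the anilide of compound 2

This account rests on a few compounds, and the source may have more. Where it says the series, first, only, none or still open, it means among the compounds named here.

Measured so far:
compound 1 `O=C(O)CCc1nnc(C(=O)Nc2cccc(-c3ccc(F)cc3)c2)s1`: 1280 nM
compound 2 `O=C(O)CCc1ccc(OCc2nnc(C(=O)Nc3ccccc3)s2)cc1`: 1060 nM

In a functional assay on CHO cells for agonist activity at Free fatty acid receptor 1 (Homo sapiens), read by calcium flux (a lower number here means that less compound is needed, a higher number that more compound is needed for the effect), compound 2 gives the lower of the two numbers, yet compound 1 with 1280 nM lies within the scatter of it, so no order between the two is claimed. Compound 3 `O=C(O)CCc1ccc(OCc2nnc(C(=O)Nc3ccccc3F)s2)cc1` carries the change fluoro in place of hydrogen on an aromatic carbon, anilino to (2-fluorophenyl)amino. Among the compounds with values here, no measured pair shows this change; the expected step is one of no size beyond the scatter, a 1.2-fold lower number from compound 2 to compound 3 (0.07 log units; within the scatter). For compound 3 the value is estimated at 900 nM, between 400 nM and 2200 nM.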

Compound 3, half-maximal effective concentration: 580 nM
For compound 3 the middle estimate is 1.6-fold (0.19 log units) above the measured one, and the stated range covers the measured number.
By their numbers in this assay, from the lowest: compounds 3, 2 and 1 (each within the scatter of the next, the first and the last beyond it).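

In this assay, within the data shown here, replacing phenyl with 2-fluorophenyl on the anilide gives a 1.8-fold lower number from compound 2 to compound 3 (0.26 log units; within the scatter), the first one-place comparison. A fluoro on this aromatic carbon, ortho to a large group, is therefore tolerated, and the two numbers cannot be ordered. No measurement available here bears on the reason for this result. On these data alone, whether a chloro, methyl or methoxy group on the same carbon would read differently remains open. So does the outcome of a fluoro on another carbon of this ring.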